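Ring replacements on the shared core: expecting compound 4

The source may hold more compounds than are shown below. What is called first, only, known or untested is meant among the compounds shown, and "the series" means these compounds.

Working notes on a small set sharing one core, varied only on a double-bonded chain carbon bound to a double-bonded chain carbon. In an ADME assay on Vero cells (Chlorocebus sabaeus) for cytotoxicity, read by MTT assay (on this read-out lower numbers stand for stronger inhibition and higher numbers for weaker inhibition), compound 1 `C=CCOc1cc(OC)c(C(=O)/C=C/c2cccc(OC)c2)c(OCC=C)c1` gives 142000 nM. Compound 2 `C=CCOc1cc(OC)c(C(=O)/C=C/c2ccccc2Br)c(OCC=C)c1` gives 13900 nM and compound 3 `C=CCOc1cc(OC)c(C(=O)/C=C/c2ccco2)c(OCC=C)c1` gives 191000 nM. Compound 1 stands second highest of the three numbers: its nearest neighbour is compound 3, its furthest compound 2. The measured steps are a 10-fold lower number from compound 1 to compound 2 (1.01 log units; beyond the scatter), a 1.3-fold higher number from compound 1 to compound 3 (0.13 log units; within the scatter) and a 14-fold higher number from compound 2 to compound 3 (1.14 log units; beyond the scatter).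

Compound 4 `C=CCOc1cc(OC)c(C(=O)/C=C/c2ccc([N+](=O)[O-])cc2)c(OCC=C)c1` is not yet measured. The change from compound 1 is 4-nitrophenyl in place of 3-methoxyphenyl on a double-bonded chain carbon bound to a double-bonded chain carbon. Among the compounds with values here, no measured step involves a 4-nitrophenyl group, so nothing bears on it directly. The two measured replacements from compound 1 show that such a swap can leave the number where it is, as in a 1.3-fold higher number from compound 1 to compound 3 (0.13 log units; within the scatter), or pull it down sharply, as in a 10-fold lower number from compound 1 to compound 2 (1.01 log units; beyond the scatter). Once more one six-membered aromatic ring of carbon only enters, as in compound 2, but the size of the step cannot be read from the data. A shift down of modest size is expected, a 1.4-fold lower number from compound 1 to compound 4 (0.15 log units; within the scatter). Compound 4 is estimated at 100000 nM in this assay, within 25000 nM to 350000 nM.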

Compound 4, half-maximal inhibitory concentration: 12600 nM
Compound 4: the middle estimate sits 7.9-fold (0.90 log units) above what was measured; the whole stated range lies above it.
By their numbers in this assay, from the lowest: compounds 4 and 2 (each within the scatter of the next); then compounds 1 and 3 (each within the scatter of the next).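

The 4-nitrophenyl result shows that the low numbers at this position in this assay do not belong to 2-bromophenyl alone: the replacement gives an 11-fold lower number from compound 1 to compound 4 (1.05 log units; beyond the scatter), and against the five-membered ring it gives a 15-fold lower number from compound 3 to compound 4 (1.18 log units; beyond the scatter). The two groups that pull the number down are different in their atoms yet end up together, with a 1.1-fold lower number from compound 2 to compound 4 (0.04 log units; within the scatter), while 3-methoxyphenyl, which carries the same six-membered aromatic ring of carbon only, remains within the scatter of furan-2-yl, so the presence of that ring does not by itself set the number at this place on the chain. No supporting measurement accounts for why 2-bromophenyl and 4-nitrophenyl part from 3-methoxyphenyl here.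

The compounds shown leave open where a plain phenyl group would fall relative to these two clusters, and so whether the bromine and nitro substituents lower the number or the methoxy substituent raises it. They also leave open how a phenyl ring bearing an amine or a carboxylic acid would behave at this position on the shared core.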